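This account rests on a few compounds, and the source may have more. Where it says the series, first, only, none or still open, it means among the compounds named here.

Measured compounds:
Compound 1 `CCNC(=O)C1=C(C)NC(=O)NC1c1ccco1`: 3%
Compound 2 `CC1=C(C(=O)OC2CCCC2)C(c2ccco2)NC(=O)N1`: 14%

Among the measured compounds shown here, in an assay on membranes from HeLa cells for displacement of a labelled ligand from adenosine receptor A3 (Homo sapiens), read by scintillation counting, with a stated time of 180 min, tested at 1 uM (on this read-out lower numbers stand for less inhibition and higher numbers for more inhibition at the one concentration tested (going by the name of the read-out)), compound 2 stands higher of the two, with compound 1 the only neighbour, and the step of a number 11 percentage points higher from compound 1 to compound 2 (beyond the scatter) swaps an amine for an ester on the carbonyl. Compound 3 `CC1=C(C(=O)OCC2CC2)C(c2ccco2)NC(=O)N1` differs from compound 2 by cyclopropylmethyl in place of cyclopentyl on an oxygen next to a carbonyl group, a change within the ester's alkyl group. The measured step does not alter that group, so it gives little guidance, and no large shift is expected: the estimated step is a number 2 percentage points lower from compound 2 to compound 3 (within the scatter), within the scatter. Compound 3 is expected to give about 12%, with a range from 0% to 28%.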

Compound 3, a percentage reported as inhibition, at one concentration (the size of the read-out at that concentration, not a potency): 1%
Compound 3: the middle estimate sits 11 percentage points above what was measured; the range from low to high includes it.
By their numbers in this assay, from the lowest: compounds 3 and 1 (each within the scatter of the next); then compound 2.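

In this assay, the group on the ester oxygen turns out to matter: with nothing else changed, cyclopropylmethyl in place of cyclopentyl gives a number 13 percentage points lower from compound 2 to compound 3 (beyond the scatter). The ester link alone is therefore not enough to lift the number, since cyclopropylmethoxy in place of ethylamino gives only a number 2 percentage points lower from compound 1 to compound 3 (within the scatter), and the earlier gain holds for the cyclopentyl ester only. Nothing available explains why these two ester groups differ. The compounds shown leave open how a cyclohexyl group or a straight butyl chain on that oxygen would read.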